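The source may hold more compounds than are shown below. What is called first, only, known or untested is meant among the compounds shown, and "the series" means these compounds.

Compound 1, `CC(C)CN1C(=O)c2ccccc2[C@H](C(=O)Nc2ccc(F)c(C#N)c2)[C@H]1c1ccsc1`, in a physicochemical assay for solubility, in phosphate buffer, with a stated time of 18 h, at pH 7 (a higher number here means a more soluble compound, a lower number a less soluble compound), gives < 1000 nM, which is a limit of the assay rather than a number.
Compound 2, `CC(C)CN1C(=O)c2ccccc2[C@H](C(=O)Nc2ccc(F)c(C#N)c2)[C@H]1c1ccco1`, gives 13000 nM in this assay.
Compound 3, `Cc1ccc([C@@H]2[C@@H](C(=O)Nc3ccc(F)c(C#N)c3)c3ccccc3C(=O)N2CC(C)C)s1`, gives < 1000 nM in this assay, again a limit rather than a number.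

Compound 1 therefore stands only at a limit, and so does one further compound in the set (the limit of < 1000 nM in this assay, at which 2 of the 3 values shown sit). Compound 4, `CC(C)CN1C(=O)c2ccccc2[C@H](C(=O)Nc2ccc(F)c(C#N)c2)[C@H]1c1ccc(C#N)s1`, carries a change on the same saturated ring carbon: 5-cyanothiophen-2-yl in place of thiophen-3-yl on a saturated ring carbon. Among the compounds with values here, two measured steps bear on this position. From the thiophene of compound 1 to the furan of compound 2 the solubility rose by an at least 13-fold higher number from compound 1 to compound 2 (1.11 log units; beyond the scatter). Going from compound 2 to compound 3, with a methyl-bearing thiophene, it fell by an at least 13-fold lower number from compound 2 to compound 3 (1.11 log units; beyond the scatter), while the step that the two limits leave unreadable from compound 1 to compound 3 cannot be read. Both thiophenes sit at the limit, so for compound 4, a third thiophene, no rise beyond the scatter is expected, and the measurement may again return only a limit. The estimate for compound 4 is 800 nM, expected between 300 nM and 3000 nM. The expected step from this estimate is a step that the limit leaves unreadable from compound 1 to compound 4.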

Compound 4, solubility: 4900 nM
Compound 4: middle estimate off by 6.1-fold (0.79 log units), on the low side; measured number above the stated range.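

Within the data shown here, compound 4 is the first thiophene here to give a number rather than a limit: the change brings an at least 4.9-fold higher number from compound 1 to compound 4 (0.69 log units; beyond the scatter), and cyano in place of methyl on the aromatic carbon brings an at least 4.9-fold higher number from compound 3 to compound 4 (0.69 log units; beyond the scatter). A thiophene on this saturated ring carbon is therefore not tied to the low end of this assay, although the furan is not matched, with a 2.7-fold lower number from compound 2 to compound 4 (0.42 log units; beyond the scatter). The first two steps each start from a limit of the assay, not from a number: the limit of < 1000 nM in this assay, at which 2 of the 4 values shown sit.

The step between the two thiophenes at the limit, compound 1 and compound 3, still cannot be read. From the compounds shown here alone, how a carboxylic acid or an aminomethyl group in place of the cyano on the same thiophene would compare with compound 2 remains open.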